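Diethylamino to propylamino on the thiocarbonyl carbon

A few compounds are considered here, and "the series" means these few. Any claim that something is new, unique, unknown or untested is made for them only; others in the source may bear on it.

Compound 2 `CCN(CC)C(=S)N/N=C\c1c[nH]c2ccccc12` stands at a limit rather than a number: in an ADME assay on KB cells (Homo sapiens) for cytotoxicity, read by MTT assay, with a stated time of 44 h (a higher number here means a weaker inhibitor, a lower number a stronger inhibitor), compound 2 gives > 100000 nM. Compound 1 `CCCCNC(=S)N/N=C\c1c[nH]c2ccccc12` likewise stands at a limit, giving > 100000 nM in this assay. For the measured compounds named here, the only measured step, a step that the two limits leave unreadable from compound 1 to compound 2, is thus unreadable, and the limit of > 100000 nM in this assay, at which 2 of the 2 values shown sit, is all that the numbers show. Compound 3 `CCCNC(=S)N/N=C\c1c[nH]c2ccccc12` carries the change (propylamino in place of diethylamino on a thiocarbonyl carbon). No readable step bears on this change, so for compound 3 the step expected is a step that the limit leaves unreadable from compound 2 to compound 3, none beyond the scatter. Compound 3 is expected at 150000 nM, between 50000 nM and 500000 nM.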

Compound 3, half-maximal inhibitory concentration: > 100000 nM
Compound 3 was reported as a limit (the forecaster's own chance of this, stated with the estimate: 85%); the middle value lies beyond the limit too.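

No step among compound 1, compound 2 and compound 3 can be read, as all three stand at a limit: the limit of > 100000 nM in this assay, at which 3 of the 3 values shown sit.

On these data alone, whether butylamino, diethylamino and propylamino on the thiocarbonyl carbon differ at all stays open.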